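This account rests on a few compounds, and the source may have more. Where it says the series, first, only, none or still open, it means among the compounds named here.

Compounds measured in a functional assay on CHO cells for agonist activity at Free fatty acid receptor 1 (Homo sapiens), read by FLIPR and calcium flux, in the presence of a further agent that is not named here; on this read-out lower numbers stand for an effect already at smaller amounts and higher numbers for an effect only at larger amounts of compound:
compound 1, `Cc1cccc(-c2noc(COc3ccc(CCC(=O)O)cc3Cl)n2)c1`, gives 4580 nM;
compound 2, `O=C(O)CCc1ccc(OCc2ncc(-c3cccc(Cl)c3)o2)cc1`, gives 47500 nM;
compound 3, `O=C(O)CCc1ccc(OCc2nc(-c3cccc(C(F)(F)F)c3)no2)c(Cl)c1`, gives 30100 nM.

Compound 3 sits well away from compound 1, beyond the scatter, while the value of compound 2 lies within the scatter of it. Among the measured compounds shown here, the single step between compounds differing in one place is a 6.6-fold higher number from compound 1 to compound 3 (0.82 log units; beyond the scatter), a modest change. Compound 4, `O=C(O)CCc1ccc(OCc2nc(-c3cccc(C(F)(F)F)c3)no2)cc1`, arises from compound 3 by hydrogen in place of chloro on an aromatic carbon. For the measured compounds named here, no measured pair shows this change alone; compound 2 also lacks the chloro but differs from compound 3 in its core as well, so its value is no clean guide. The step from compound 3 to compound 4 is therefore expected to stay small, a 1.0-fold lower number from compound 3 to compound 4 (0.00 log units; within the scatter), with no firm direction. Compound 4 is estimated at 30000 nM in this assay, within 10000 nM to 90000 nM.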

Compound 4, half-maximal effective concentration: 1110 nM
Estimate against measurement, compound 4: 27-fold (1.43 log units) above; the measured number lies below the stated range.
By their numbers in this assay, from the lowest: compound 4; then compound 1; then compounds 3 and 2 (each within the scatter of the next).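

In this assay, hydrogen in place of chloro gives a 27-fold lower number from compound 3 to compound 4 (1.43 log units; beyond the scatter), a large step. Among the compounds shown here, this position, ortho to a large group and meta to a 2-carboxyethyl group, therefore matters far more than the earlier compounds could show, since none of them isolated this change. Nothing available here accounts for the size of this step. Going by these compounds, whether fluoro, methoxy or a nitrile at this position would give a number closer to compound 4 or to compound 3 stays open. Also open, on these data alone, is whether the same change would act alike on compound 1, which carries methyl in place of trifluoromethyl.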